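From dimethylsulfamoyl to ethylcarbamoyl: expected cytotoxicity

This account rests on a few compounds, and the source may have more. Where it says the series, first, only, none or still open, it means among the compounds named here.

Within the data shown here, compound 2 `CN(C)S(=O)(=O)NC[C@H]1CN(c2ccc(-n3cc(-c4ccccn4)cn3)c(F)c2)C(=O)O1` is the only compound with a definite number: in an ADME assay on HEK293-A cells (Homo sapiens) for cytotoxicity, read by MTT assay, with a stated time of 48 h (on this read-out lower numbers stand for stronger inhibition and higher numbers for weaker inhibition), compound 2 gives 249 ug/mL. Compound 1 `O=C1CNC(=O)N1C[C@H]1CN(c2ccc(-n3cc(-c4ccccn4)cn3)c(F)c2)C(=O)O1` is reported only as a limit, > 400 ug/mL. Among the measured compounds shown here, the sole measured step, an at least 1.6-fold lower number from compound 1 to compound 2 (0.20 log units; that floor lies within the scatter), rests on that limit of > 400 ug/mL in this assay, at which 1 of the 2 values shown sits, and its floor lies within the scatter. Compound 3 `CCNC(=O)NC[C@H]1CN(c2ccc(-n3cc(-c4ccccn4)cn3)c(F)c2)C(=O)O1` differs from compound 2 by ethylcarbamoyl in place of dimethylsulfamoyl on an amine nitrogen. For the measured compounds named here, no measured step covers this exchange, so compound 3 is expected to move only by a 1.1-fold higher number from compound 2 to compound 3 (0.05 log units; within the scatter), nothing beyond the scatter. Compound 3 is therefore estimated at 280 ug/mL, within 140 ug/mL to 450 ug/mL.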

Compound 3, half-maximal inhibitory concentration: 29 ug/mL
Compound 3: middle estimate off by 9.7-fold (0.98 log units), on the high side; the measured number lies below the stated range.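

In this assay, ethylcarbamoyl in place of dimethylsulfamoyl on an amine nitrogen gives an 8.6-fold lower number from compound 2 to compound 3 (0.93 log units; beyond the scatter), so this position can move the number well beyond the scatter, which the earlier pair could not show. Measured against 2,5-dioxoimidazolidin-1-yl, the (ethylcarbamoyl)amino group gives an at least 13-fold lower number from compound 1 to compound 3 (1.13 log units; beyond the scatter). That size is only a floor, and compound 1 is reported only as a limit: the limit of > 400 ug/mL in this assay, at which 1 of the 3 values shown sits.

Going by these compounds, whether the change follows the ethyl chain or the carbonyl stays open. A methylcarbamoyl, a longer chain on the carbamoyl or an acetyl on the same nitrogen could separate the two.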